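The source may hold more compounds than are shown below. What is called first, only, known or untested is meant among the compounds shown, and "the series" means these compounds.

Compound 3 `CC1=CCC(O)C(C)(C)C1Cc1c(O)ccc2c1O[C@H](c1ccc(O)cc1)CC2=O` is one of three compounds that share a common core and differ only in the side chain attached to it. In a functional assay on KB cells (Homo sapiens) for cytotoxicity, read by MTT assay (on this read-out lower numbers stand for stronger inhibition and higher numbers for weaker inhibition), compound 3 gives > 10000 nM, which is a limit of the assay rather than a measured number. Compound 1 `COC(C)(C)/C=C/C/C(C)=C/Cc1c(O)ccc2c1O[C@H](c1ccc(O)cc1)CC2=O` gives > 10000 nM in this assay, again a limit. Compound 2 `COC(C=C(C)C)C/C(C)=C/Cc1c(O)ccc2c1O[C@H](c1ccc(O)cc1)CC2=O` gives > 10000 nM, also a limit. For the measured compounds named here, all three values thus sit together at the same limit (the limit of > 10000 nM in this assay, at which 3 of the 3 values shown sit), and the single step between measured compounds that differ in one place, a step that the two limits leave unreadable from compound 1 to compound 2, cannot be read because both ends are limits. Compound 4 `CC(C)=CCC/C(C)=C/Cc1c(O)ccc2c1O[C@H](c1ccc(O)cc1)CC2=O` differs from compound 3 by the change (2,6-dimethylhepta-1,5-dien-1-yl in place of 5-hydroxy-2,6,6-trimethylcyclohex-2-en-1-yl on a saturated chain carbon bound to an aromatic carbon). No readable measured step bears on this change, so no size or direction can be drawn from the data beyond the fact that every value shown sits at the limit. Compound 4 is therefore expected to fall at or near that limit as well, with a step that the limit leaves unreadable from compound 3 to compound 4 estimated to be small. Compound 4 is estimated at 20000 nM, within a range from 5000 nM to 100000 nM.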

Compound 4, half-maximal inhibitory concentration: > 10000 nM
Compound 4: only a limit was reported; the forecaster's own chance of this, stated with the estimate: 80%; the middle value does not contradict the limit.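

For the compounds shown here, compound 4 sits at a limit of the assay, as do compound 1, compound 2 and compound 3, so no step from any of them to compound 4 can be read: the limit of > 10000 nM in this assay, at which 4 of the 4 values shown sit.

The compounds shown leave open whether these side chains differ at all in this assay, as every true value lies hidden behind the limit.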